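The source may hold more compounds than are shown below. What is called first, only, known or untested is meant among the compounds shown, and "the series" means these compounds.

Working notes on the series.

Compound 1 `CN(C)CCNc1nc(-c2ccc(NC(=O)Nc3ccc(Cl)cc3)cc2)nc2ccsc12` carries a 4-chlorophenyl on the urea nitrogen and in a functional assay on MKN-45 cells (Homo sapiens) for cytotoxicity, read by MTT assay, with a stated time of 72 h (a lower number here means a stronger inhibitor, a higher number a weaker inhibitor), compound 1 gives 250 nM. Compound 2 `CN(C)CCNc1nc(-c2ccc(NC(=O)Nc3ccccc3Cl)cc2)nc2ccsc12` is its 2-chlorophenyl counterpart, the difference being (2-chlorophenyl in place of 4-chlorophenyl on an amide-type nitrogen), and in this assay compound 2 gives 850 nM; the step of a 3.4-fold higher number from compound 1 to compound 2 (0.53 log units; beyond the scatter) is thus a loss of potency beyond the scatter. Compound 3 `CCN(CC)CCNc1nc(-c2ccc(NC(=O)Nc3ccc(Cl)cc3)cc2)nc2c(Cl)c(Cl)sc12` rests on a different core, and the difference between the two cores is not broken down here; in this assay compound 3 gives 890 nM, a number indistinguishable from that of compound 2 and clearly higher than that of compound 1.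

Compound 4 `CCN(CC)CCNc1nc(-c2ccc(NC(=O)Nc3ccccc3Cl)cc2)nc2c(Cl)c(Cl)sc12` is not yet measured. Its difference from compound 3 is 2-chlorophenyl in place of 4-chlorophenyl on an amide-type nitrogen, the same change, at the same place, as that between compound 1 and compound 2. For the measured compounds named here, a step of comparable direction and size is expected from compound 3 to compound 4, a 2.8-fold higher number from compound 3 to compound 4 (0.45 log units; beyond the scatter), because a 3.4-fold higher number from compound 1 to compound 2 (0.53 log units; beyond the scatter) is the only measured instance of this change and nothing points the other way. For compound 4 in this assay the expected value is 2500 nM, with a likely range from 900 nM to 7000 nM.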

Compound 4, half-maximal inhibitory concentration: 1130 nM
The estimate for compound 4 lay 2.2-fold (0.34 log units) above the measured number; low and high end bracket the measured number.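

On the core of compound 3, 2-chlorophenyl in place of 4-chlorophenyl on the urea nitrogen gives, in this assay, a 1.3-fold higher number from compound 3 to compound 4 (0.10 log units; within the scatter), so the loss of potency seen on the core of compound 1 does not reappear on this core. The size of this step therefore does not carry from one core to the other, and the gap between the two steps is larger than repeated measurement would account for: the same change on two cores in this assay, a 3.4-fold higher number (0.53 log units; beyond the scatter) from compound 1 to compound 2 and a 1.3-fold higher number (0.10 log units; within the scatter) from compound 3 to compound 4, 2.7-fold (0.43 log units) apart, beyond the scatter of two such steps. This rests on a single pair per core and does not show why the steps differ, which part of the difference between the cores matters, or how the change would behave on any further core.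

Still open, from the compounds shown here alone, is whether an unsubstituted phenyl or a pyridine ring on the urea nitrogen would depend on the core in the same way. Also open, going by these compounds, is whether the dimethylamino and diethylamino ends of the side chain, taken apart from the rest of the core, have any bearing on the step.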